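The compounds below may be only part of what the source reports. "The series", "measured", "known", "first", "only" and "open" are said of these compounds alone.

Measured so far:
Compound 1 `CC[C@H](NC(C)=O)c1cc(Cl)ccc1C1CCN(C(=O)[C@@H]2CN(C(C)(C)C)C[C@H]2c2ccc(Cl)cc2Cl)CC1`: 48%
Compound 2 `CC[C@H](NC(C)=O)c1cc(Cl)ccc1C1CCN(C(=O)[C@@H]2CN(C(C)(C)C)C[C@H]2c2ccc(F)cc2Cl)CC1`: 84%
Compound 3 `CC[C@H](NC(C)=O)c1cc(Cl)ccc1C1CCN(C(=O)[C@H]2CN(C(C)(C)C)C[C@@H]2c2ccc(Cl)cc2F)CC1`: 45%

In a functional assay on CHO cells for agonist activity at Melanocortin receptor 4 (Homo sapiens), read by cAMP accumulation (on this read-out lower numbers stand for smaller maximal responses and higher numbers for larger maximal responses), compound 3 gives the lowest of the three numbers; compound 1 is within the scatter of it, while compound 2 lies well beyond it. Compound 4 `CC[C@H](NC(C)=O)c1cc(Cl)ccc1C1CCN(C(=O)[C@@H]2CN(C(C)(C)C)C[C@H]2c2ccc(Cl)cc2F)CC1` differs from compound 3 only in configuration: the two compounds have the same atoms and bonds and differ only in configuration as drawn: 2 of 3 stereo elements differ; a stereocentre at a saturated ring carbon is drawn R in compound 3 and S in compound 4; a stereocentre at a saturated ring carbon is drawn S in compound 3 and R in compound 4. Among the compounds with values here, the one measured step, a number 36 percentage points higher from compound 1 to compound 2 (beyond the scatter), concerns an exchange of halogen, not a change in configuration, so no measured step bears directly on this change. The expectation for compound 4 is therefore uncertain, and a step of a number 15 percentage points higher from compound 3 to compound 4 (beyond the scatter) is estimated, with wide bounds. Compound 4 is expected to give about 60%, within a range of 35% to 90%.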

Compound 4, largest response reached (reported as percent of maximum), in percent of the reference or control that the assay uses: 97%
Estimate against measurement, compound 4: 37 percentage points below, outside the stated range (above it).
By their numbers in this assay, from the lowest: compounds 3 and 1 (each within the scatter of the next); then compound 2; then compound 4.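

Configuration alone proves decisive in this assay, with a number 52 percentage points higher from compound 3 to compound 4 (beyond the scatter), and this step can be set down to the two saturated ring carbons because nothing else changes: the fact that compounds 3 and 4 differ only in the configuration as drawn. Within the configuration shared by compound 1, compound 2 and compound 4, the halogens also count: fluoro in place of chloro brings a number 49 percentage points higher from compound 1 to compound 4 (beyond the scatter), while 4-chloro-2-fluorophenyl in place of 2-chloro-4-fluorophenyl brings a number 13 percentage points higher from compound 2 to compound 4 (beyond the scatter). Going by these compounds, the two ring carbons change together in this pair, and their separate shares remain open. Also open, on these data alone, is how a methoxy group or a nitrile in place of the halogens would read in this assay.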